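The source may hold more compounds than are shown below. What is called first, only, known or untested is meant among the compounds shown, and "the series" means these compounds.

Series notes. Compound 1 `COc1cc(-c2nn(-c3cccc(NC(=O)c4cccc(C(F)(F)F)c4)c3)cc2-c2ccncc2)ccc1Cl`, compound 2 `COc1cc(-c2nn(-c3cccc(NC(=O)Nc4ccc(Cl)c(Cl)c4)c3)cc2-c2ccncc2)ccc1Cl` and compound 3 `COc1cc(-c2nn(-c3cccc(NC(=O)Nc4cccc(C(F)(F)F)c4)c3)cc2-c2ccncc2)ccc1Cl` share one core and differ only at the carbonyl carbon of the anilide. In a functional assay on SK-OV-3 cells (Homo sapiens) for inhibition, read by sulforhodamine B assay, with a stated time of 48 h (on this read-out lower numbers stand for stronger inhibition of growth and higher numbers for weaker inhibition of growth), compound 1 gives 2290 nM, compound 2 gives 1930 nM and compound 3 gives 2020 nM; compound 3 thus holds the second highest of the three values, all within the scatter of one another. Compound 4 `COc1cc(-c2nn(-c3cccc(NC(=O)c4ccc(Cl)c(C(F)(F)F)c4)c3)cc2-c2ccncc2)ccc1Cl` is not yet measured; it differs from compound 3 by 4-chloro-3-(trifluoromethyl)phenyl in place of (3-(trifluoromethyl)phenyl)amino on a carbonyl carbon. Among the compounds with values here, the steps that bear on it, a 1.1-fold lower number from compound 1 to compound 3 (0.05 log units; within the scatter), a 1.2-fold lower number from compound 1 to compound 2 (0.07 log units; within the scatter) and a 1.0-fold higher number from compound 2 to compound 3 (0.02 log units; within the scatter), were all flat, whether the carbonyl carries an arylamino group or an aryl group. No step beyond the scatter is therefore expected in this assay; the expected step of a 1.0-fold higher number from compound 3 to compound 4 (0.02 log units; within the scatter) is small, and compound 4 is estimated at 2100 nM, range 1000 nM to 4500 nM.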

Compound 4, concentration for 50% growth inhibition: 9290 nM
Compound 4: the middle estimate sits 4.4-fold (0.65 log units) below what was measured; measured number outside the range, above it.
By their numbers in this assay, from the lowest: compounds 2, 3 and 1 (each within the scatter of the next); then compound 4.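

In this assay this position is no longer flat: chloro in place of hydrogen on an aromatic carbon gives a 4.1-fold higher number from compound 1 to compound 4 (0.61 log units; beyond the scatter), so this single change matters where exchanging aryl and arylamino groups on the carbonyl carbon did not. The replacements on that carbon now also read as real steps, with a 4.6-fold higher number from compound 3 to compound 4 (0.66 log units; beyond the scatter) and a 4.8-fold higher number from compound 2 to compound 4 (0.68 log units; beyond the scatter). Nothing measured here accounts for the loss. Going by these compounds, whether fluoro, methyl or methoxy in place of that chloro would cost as much stays open. So does whether a (4-chloro-3-(trifluoromethyl)phenyl)amino group on the carbonyl carbon would stay level with compound 3.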